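A few compounds are considered here, and "the series" means these few. Any claim that something is new, unique, unknown or untested is made for them only; others in the source may bear on it.

Measured so far in a functional assay on 143B cells (Homo sapiens) for antiproliferative activity, read by MTT assay, with a stated time of 48 h; a lower number here means a stronger inhibitor, a higher number a weaker inhibitor:

Compound 1 `O=C(/C=C/c1cccc(NC(=O)c2ccccc2Br)c1)c1nc2ccccc2[nH]1`: 6050 nM
Compound 2 `O=C(/C=C/c1cccc(NS(=O)(=O)c2ccc(Cl)cc2)c1)c1nc2ccccc2[nH]1`: 7450 nM

For the measured compounds named here, compound 2 has only one neighbour in this assay, compound 1, and the step of a 1.2-fold higher number from compound 1 to compound 2 (0.09 log units; within the scatter) leaves the two numbers within the scatter of each other, so compound 2 stands level with compound 1 rather than apart from it.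

Compound 3 `Cc1ccc(S(=O)(=O)Nc2cccc(/C=C/C(=O)c3nc4ccccc4[nH]3)c2)cc1C` keeps the sulfonamide of compound 2 and differs only in the aryl on the sulfonyl sulfur: 3,4-dimethylphenyl in place of 4-chlorophenyl on a sulfonyl sulfur.

Going by the values given here, no measured step touches a substituent change on the sulfonyl aryl. Among the compounds with values here, the single step measured, a 1.2-fold higher number from compound 1 to compound 2 (0.09 log units; within the scatter), exchanges the whole acyl group for the sulfonyl group and still stays within the scatter, which gives no sign that this part of the molecule moves the number much. Compound 3 is therefore expected to stay close to compound 2, with an estimated step of a 1.1-fold lower number from compound 2 to compound 3 (0.03 log units; within the scatter) and an estimated value of 7000 nM, within 3000 nM to 17000 nM.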

Compound 3, half-maximal inhibitory concentration: 5050 nM
Compound 3: the middle estimate sits 1.4-fold (0.14 log units) above what was measured; measured number inside the range.
By their numbers in this assay, from the lowest: compounds 3, 1 and 2 (each within the scatter of the next).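

For the compounds shown here, this is the first measured change on the aryl carried by the sulfonyl sulfur: in this assay, 3,4-dimethylphenyl in place of 4-chlorophenyl gives a 1.5-fold lower number from compound 2 to compound 3 (0.17 log units; within the scatter) and so does not separate the two aryl groups. The earlier exchange of the whole acyl group for the sulfonyl group, a 1.2-fold higher number from compound 1 to compound 2 (0.09 log units; within the scatter), also lies within the scatter, so neither of the two steps on this side of the molecule resolves a difference among compounds 1, 2 and 3. No supporting measurement is available to explain this result.

As far as these compounds go, whether this position tolerates groups of a different kind remains open, for example an amine or a carboxylic acid on the sulfonyl aryl. The compounds shown also share one core, so how changes to that core would affect the number is unknown.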